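Hydroxyphenyl position on the shared core

The source may hold more compounds than are shown below. What is called first, only, known or untested is meant among the compounds shown, and "the series" means these compounds.

Of the compounds shown here, three have been measured in a functional assay on DU-145 cells (Homo sapiens) for inhibition; on this read-out lower numbers stand for stronger inhibition and higher numbers for weaker inhibition. Compound 1 `Oc1cccc(-c2cc(-c3ccc(F)cc3)cc(-c3cccc(O)c3)n2)c1` gives 7120 nM. Compound 2 `Oc1ccc(-c2cc(-c3ccc(F)cc3)cc(-c3cccc(O)c3)n2)cc1` gives 15200 nM. Compound 3 `Oc1ccc(-c2cc(-c3cccc(OC(F)(F)F)c3)cc(-c3cccc(O)c3)n2)cc1` gives 5670 nM, the lowest of the three numbers, though its gap to compound 1 lies within the scatter.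

The change from compound 1 to compound 2 is 4-hydroxyphenyl in place of 3-hydroxyphenyl on an aromatic carbon, and it gave a 2.1-fold higher number from compound 1 to compound 2 (0.33 log units; beyond the scatter).

Compound 4 `Oc1ccc(-c2cc(-c3cccc(OC(F)(F)F)c3)cc(-c3ccc(O)cc3)n2)cc1` is not yet measured. It differs from compound 3 by 4-hydroxyphenyl in place of 3-hydroxyphenyl on an aromatic carbon, the same kind of change as that from compound 1 to compound 2, though the surroundings differ: in compound 1 the place is meta to a 3-hydroxyphenyl group and meta to a 4-fluorophenyl group, in compound 3 it is meta to a 4-hydroxyphenyl group and meta to a large group. The difference between the cores of compound 1 and compound 3 is not broken down here.

For the measured compounds named here, from compound 3 to compound 4 a step of about a 2.1-fold higher number from compound 3 to compound 4 (0.33 log units; beyond the scatter) is expected, because the one earlier instance gave a 2.1-fold higher number from compound 1 to compound 2 (0.33 log units; beyond the scatter). Compound 4 is therefore estimated at 12000 nM, most likely between 6000 nM and 25000 nM.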

Compound 4, half-maximal inhibitory concentration: > 50000 nM
Compound 4: no number, only a limit; the forecaster's own chance of this, stated with the estimate: 10%; middle value at least 4.1-fold (0.61 log units) from the limit.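

In this assay the change runs in the same direction on both cores, with an at least 8.8-fold higher number from compound 3 to compound 4 (0.94 log units; beyond the scatter). Its size does not carry over from one core to the other: the same change on two cores in this assay, a 2.1-fold higher number (0.33 log units; beyond the scatter) from compound 1 to compound 2 and an at least 8.8-fold higher number (0.94 log units; beyond the scatter) from compound 3 to compound 4, at least 4.1-fold (0.61 log units) apart, beyond the scatter of two such steps. Compound 4 gives > 50000 nM, which is a limit of the assay and not a number, so the full size of its step remains unread, and two pairs do not show which difference between the cores goes with the larger step: the limit of > 50000 nM in this assay, at which 1 of the 4 values shown sits.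

The compounds shown leave open how the step behaves when the hydroxyl of the moved group gives way to an amine or a carboxylic acid. They also leave open whether the step on a further core would lie nearer the one seen on the core of compound 1 or the one seen on the core of compound 3.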